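The source may hold more compounds than are shown below. What is called first, only, known or untested is meant among the compounds shown, and "the series" means these compounds.

Among the measured compounds shown here, in a functional assay (Homo sapiens) for inhibition of Nucleic Acid, tested at 100 uM (a lower number here means less inhibition, a higher number more inhibition at the concentration tested (going by the name of the read-out)), compound 2 `OC[C@H]1OC(n2cnc3c(Cl)nccc32)[C@H](O)[C@@H]1O` gives 76%, the higher of the two numbers measured so far. Compound 1 `CSc1nccc2c1ncn2C1O[C@H](CO)[C@@H](O)[C@H]1O` gives 24%. For the measured compounds named here, the only measured step shows a number 52 percentage points higher from compound 1 to compound 2 (beyond the scatter). Compound 3 `CNc1nccc2c1ncn2C1O[C@H](CO)[C@@H](O)[C@H]1O` differs from compound 2 by methylamino in place of chloro on an aromatic carbon. Going by the values given here, that one step is the sole guide, and it shows that exchanging the group at this carbon can shift the number far. Because the step of a number 52 percentage points higher from compound 1 to compound 2 (beyond the scatter) rose strongly on arriving at chloro, leaving chloro again is expected to cost inhibition, estimated as a number 41 percentage points lower from compound 2 to compound 3 (beyond the scatter). Compound 3 is therefore expected to give 35%, between 10% and 70%.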

Compound 3, a percentage reported as inhibition, at one concentration (the size of the read-out at that concentration, not a potency): 8%
For compound 3 the middle estimate is 27 percentage points above the measured one; the whole stated range lies above it.
By their numbers in this assay, from the lowest: compound 3; then compound 1; then compound 2.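

In this assay, the step to methylamino is a number change of its own size: a number 68 percentage points lower from compound 2 to compound 3 (beyond the scatter). It also differs from methylsulfanyl, with a number 16 percentage points lower from compound 1 to compound 3 (beyond the scatter), so the two groups that replace chloro at this aromatic carbon are not equivalent, and of the three groups, chloro alone gives high inhibition. Nothing available here explains why these groups differ. Open, from the compounds shown here alone, is whether the high number is special to chloro or would also appear with another halogen such as bromine or fluorine. A plain amino group would show whether the methyl of methylamino matters.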